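Compound 4: a Longer Carboxy-Bearing Arm Under Cytotoxicity Testing

The compounds below may be only part of what the source reports. "The series", "measured", "known", "first", "only" and "open" are said of these compounds alone.

Three compounds built on one shared core have been examined in an ADME assay on MT2 cells (Homo sapiens) for cytotoxicity, read by XTT assay, with a stated time of 4 days; a lower number here means that less compound is tolerated, a higher number that more compound is tolerated. Compound 1 `Cc1ccc(C)n1-c1ccc(-c2ccccc2)c(C(=O)O)c1` gives 290000 nM. Compound 2 `Cc1ccc(C)n1-c1ccc(-c2ccc(C(=O)O)cc2)c(C(=O)O)c1` gives 355000 nM, and compound 3 `Cc1ccc(C)n1-c1ccc(O)c(C(=O)O)c1` gives 334000 nM. The three numbers lie close together: the step of a 1.2-fold higher number from compound 1 to compound 2 (0.09 log units; within the scatter) and the step of a 1.2-fold higher number from compound 1 to compound 3 (0.06 log units; within the scatter) are both within the scatter, and the values of compound 2 and compound 3 differ by even less, so none of the three can be set apart from the others in this assay.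

Compound 4 `Cc1ccc(C)n1-c1ccc(-c2ccc(/C=C/C(=O)O)cc2)c(C(=O)O)c1` is derived from compound 2 by the change (2-carboxyethenyl in place of carboxy on an aromatic carbon). Among the compounds with values here, the one measured step that touches the same aromatic carbon, the step of a 1.2-fold higher number from compound 1 to compound 2 (0.09 log units; within the scatter), was flat, and the step of a 1.2-fold higher number from compound 1 to compound 3 (0.06 log units; within the scatter) was flat as well. Within the data shown here, nothing among the measured compounds suggests that the 2-carboxyethenyl group would shift the tolerated concentration in this assay in either direction. Compound 4 is therefore expected to give about 330000 nM in this assay, with a range from 150000 nM to 650000 nM. This expected value amounts to a step of a 1.1-fold lower number from compound 2 to compound 4 (0.03 log units; within the scatter), which is estimated to remain within the scatter.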

Compound 4, half-maximal cytotoxic concentration: 255000 nM
Beside the measured number, compound 4's estimate is 1.3-fold (0.11 log units) above it; the measured number falls inside the stated range.
By their numbers in this assay, from the lowest: compounds 4, 1, 3 and 2 (each within the scatter of the next).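

In this assay, the aromatic carbon para to a large group now carries hydrogen in compound 1, carboxy in compound 2 and 2-carboxyethenyl in compound 4, and both new steps remain within the scatter: a 1.4-fold lower number from compound 2 to compound 4 (0.14 log units; within the scatter) and a 1.1-fold lower number from compound 1 to compound 4 (0.06 log units; within the scatter). Within the data shown here, the earlier compounds showed only that adding a carboxy group at this place left the number within the scatter, whereas these steps extend that finding to a larger acid-bearing group, with 5 heavy atoms in place of 3 and 2 double bonds outside aromatic rings in place of 1. No available evidence bears on why the numbers of these compounds stay so close together.

On these data alone, it remains open whether an amine, an amide or a longer chain ending in a carboxylic acid at this same aromatic carbon would also stay within the scatter of compound 2. As far as these compounds go, it is equally open whether a methyl ester in place of the carboxy group carried on the shared core by all four compounds would leave the number within the scatter.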